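Extending the phenyl tail toward naphthalen-1-yl

The source may report more compounds than this note shows. Statements on the series, on what has been measured and on what is new or still open speak of the compounds shown alone.

Compound 1 `NC(=O)c1ccc2[nH]c(-c3ccc4[nH]c(-c5ccccc5)nc4c3)nc2c1` — > 25000 nM
Compound 2 `Cc1ccccc1-c1nc2cc(-c3nc4cc(C(N)=O)ccc4[nH]3)ccc2[nH]1` — 8200 nM
Compound 3 `Cc1cccc(-c2nc3cc(-c4nc5cc(C(N)=O)ccc5[nH]4)ccc3[nH]2)c1` — 8200 nM

Three compounds share one core and differ only in the aryl group attached at the end. In a functional assay on RPMI 8402 cells (Homo sapiens) for cytotoxicity (a higher number here means a weaker inhibitor, a lower number a stronger inhibitor), compound 1 gives a value that is only a limit of the assay, > 25000 nM, (the limit of > 25000 nM in this assay, at which 1 of the 3 values shown sits). Compound 2 gives 8200 nM in this assay. Compound 3, which carries a 3-methylphenyl, gives 8200 nM in this assay and stands level with compound 2. Both methyl substitutions improved on compound 1: an at least 3.0-fold lower number from compound 1 to compound 2 (0.48 log units; beyond the scatter) and an at least 3.0-fold lower number from compound 1 to compound 3 (0.48 log units; beyond the scatter), whereas the shift of the methyl gave no change at the digits printed from compound 2 to compound 3 (within the scatter).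

Compound 4 `NC(=O)c1ccc2[nH]c(-c3ccc4[nH]c(-c5cccc6ccccc56)nc4c3)nc2c1` is the next step. The change is naphthalen-1-yl in place of 3-methylphenyl on an aromatic carbon. Going by the values given here, no measured step adds a second fused ring, so the nearest guide is that extra carbon on this aryl group has helped so far; the expectation is a small further gain or no change beyond the scatter. Compound 4 is estimated at 6000 nM, between 2000 nM and 20000 nM, meaning an expected step of a 1.4-fold lower number from compound 3 to compound 4 (0.14 log units; within the scatter).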

Compound 4, half-maximal inhibitory concentration: 3700 nM
The estimate for compound 4 lay 1.6-fold (0.21 log units) above the measured number; the measured number falls inside the stated range.
By their numbers in this assay, from the lowest: compound 4; then compounds 2 and 3 (each within the scatter of the next). At a limit, above all of these: compound 1.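

In this assay, naphthalen-1-yl on this aromatic carbon between two ring nitrogen atoms outdoes both methylphenyl tails, with a 2.2-fold lower number from compound 3 to compound 4 (0.35 log units; beyond the scatter) and a 2.2-fold lower number from compound 2 to compound 4 (0.35 log units; beyond the scatter). Moving the methyl had changed nothing, so this is the first sign that the tail can gain beyond what a single methylphenyl ring gives, and a second six-membered aromatic ring is tolerated here. Against compound 1 the step is an at least 6.7-fold lower number from compound 1 to compound 4 (0.82 log units; beyond the scatter), and it gives only a bound, since the value of compound 1 is a limit of the assay: the limit of > 25000 nM in this assay, at which 1 of the 4 values shown sits.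

The compounds shown cannot tell whether the gain depends on how the second ring is attached, which naphthalen-2-yl would test. On these data alone, whether a pyridinyl tail, or a phenyl tail carrying an amine, would keep the gain also stays open.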